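The compounds below may be only part of what the source reports. "The series", "measured", "known", "first", "only" and "open" are said of these compounds alone.

The three compounds share one core, and all were tested in a functional assay on IGROV-1 cells (Homo sapiens) for cytotoxicity, read by sulforhodamine B assay, with a stated time of 48 h, tested at 100 uM; on this read-out higher numbers stand for a weaker effect at the one concentration tested and lower numbers for a stronger effect. Compound 1, `COc1ccc(-c2cc(/C=C/C(=O)c3ccc(N)cc3)[nH]n2)cc1`, gives -67% in this assay. Compound 2, `COc1cc(-c2cc(/C=C/C(=O)c3ccc(N)cc3)[nH]n2)cc(OC)c1OC`, gives -49%. Compound 3, `COc1ccc(C(=O)/C=C/c2cc(-c3cc(OC)c(OC)c(OC)c3)n[nH]2)cc1OC`, gives -73%. Compound 2 thus stands highest of the three numbers, that is, weakest at the one concentration tested; compound 1 is the nearest to it and compound 3 the furthest, both beyond the scatter.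

The unmeasured compound 4, `COc1ccc(-c2cc(/C=C/C(=O)c3ccc(N)cc3)[nH]n2)cc1OC`, differs from compound 2 in one place: hydrogen in place of methoxy on an aromatic carbon. Among the measured compounds shown here, of the measured steps, only one is a single change, a number 24 percentage points lower from compound 2 to compound 3 (beyond the scatter), and it concerns a change on the carbonyl side of the molecule, not the methoxy groups, so it does not bear on the present change. For the measured compounds named here, compound 1 and compound 2 differ in more than one place, so no step between them is given; their values simply show that the compound with fewer methoxy groups, compound 1, has the lower number. Compound 4 carries a methoxy count between the two, so a modest step downward from compound 2 is expected, a number 9 percentage points lower from compound 2 to compound 4 (within the scatter), within a wide range. Compound 4 is therefore estimated at -58% in this assay, between -75% and -42%.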

Compound 4, a percentage reported as activity, at one concentration (the size of the read-out at that concentration, not a potency): -62%
Beside the measured number, compound 4's estimate is 4 percentage points above it; measured number inside the range.
By their numbers in this assay, from the lowest: compounds 3, 1 and 4 (each within the scatter of the next, the first and the last beyond it); then compound 2.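

In this assay, replacing one methoxy of compound 2 with hydrogen on an aromatic carbon gives a number 13 percentage points lower from compound 2 to compound 4 (beyond the scatter). Among the compounds shown here, this isolates a single methoxy on this ring as enough to shift the read-out towards a stronger effect, which the earlier compounds could not show, as compound 1 and compound 2 differ in more than one place. The neighbouring single change does not repeat the shift: methoxy in place of hydrogen gives a number 5 percentage points higher from compound 1 to compound 4 (within the scatter), so on this ring the loss of one methoxy can be read, while the presence or absence of the other cannot, and nothing available explains this difference.

Still open, from the compounds shown here alone, is whether the shift depends on hydrogen itself or only on the loss of methoxy, a question that a hydroxy group, a fluorine or a longer chain such as ethoxy on the same aromatic carbon would address. Also open, going by these compounds, is whether the step keeps its size when 3,4-dimethoxyphenyl stands in place of 4-aminophenyl on the carbonyl carbon, as it does in compound 3.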